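Sulfonamide chain on the piperidine nitrogen of a 5-HT4 antagonist

A few compounds are considered here, and "the series" means these few. Any claim that something is new, unique, unknown or untested is made for them only; others in the source may bear on it.

Compound 1 `CCCC1CCN(CCCCC(=O)c2cc(Cl)c(N)cc2OCc2cc(OC)cc(OC)c2)CC1`: 7.7
Compound 2 `COc1cc(COc2cc(N)c(Cl)cc2C(=O)CCCCN2CCC(NC(N)=O)CC2)cc(OC)c1`: 8.5
Compound 3 `CCCCN1CCC(CCC(=O)c2cc(Cl)c(N)cc2OCc2cc(OC)cc(OC)c2)CC1`: 8.9

In a functional assay for antagonist activity at 5-hydroxytryptamine receptor 4 (Rattus norvegicus) (on this read-out lower numbers stand for lower potency and higher numbers for higher potency (the scale is a negative logarithm)), compound 3 stands highest of the three, with the step of a number 0.40 log units higher from compound 2 to compound 3 (beyond the scatter) and the step of a number 1.20 log units higher from compound 1 to compound 3 (beyond the scatter) both beyond the scatter. Compound 4 `COc1cc(COc2cc(N)c(Cl)cc2C(=O)CCC2CCN(CCN(C)S(C)(=O)=O)CC2)cc(OC)c1` differs from compound 3 by methyl(methylsulfonyl)amino in place of ethyl on a saturated chain carbon, two bonds along the chain from an amine nitrogen in a ring. Among the compounds with values here, no measured step alters this position; the nearest guide is a number 0.80 log units higher from compound 1 to compound 2 (beyond the scatter), where ureido replaced propyl on a saturated ring carbon and gave a modest gain. On that analogy a small step is expected, a number 0.10 log units higher from compound 3 to compound 4 (within the scatter), which may not clear the scatter. Compound 4 is therefore estimated at 9, within 8.3 to 9.6.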

Compound 4, negative logarithm of the antagonist equilibrium constant: 9.1
Estimate against measurement, compound 4: 0.10 log units below; measured number inside the range.
By their numbers in this assay, from the lowest: compound 1; then compound 2; then compounds 3 and 4 (each within the scatter of the next).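

In this assay, putting methyl(methylsulfonyl)amino in place of ethyl on this saturated chain carbon gives a step within the scatter (a number 0.20 log units higher from compound 3 to compound 4 (within the scatter)), so the read-out does not separate compound 3 from compound 4. This position therefore accepts a group of six heavy atoms with two hydrogen-bond acceptors in place of two carbons, with no measurable loss of potency. No available evidence explains this result.

The compounds shown leave open whether a carboxylic acid or an amine at this position would fare the same. They also leave open whether a longer chain carrying the methyl(methylsulfonyl)amino group would do so.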